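Chain hydroxy replaced by hexyl in a membrane-potential series

The source may hold more compounds than are shown below. What is called first, only, known or untested is meant among the compounds shown, and "the series" means these compounds.

Two compounds of the series carry numbers in a functional assay on cells (Lymphocyte, Homo sapiens) for inhibition, read by flow cytometry, using a membrane potential dye, with a stated time of 16 h, tested at 100 nM; a lower number here means a weaker effect, a higher number a stronger effect of the compound at the concentration tested. Compound 1 `CCCCCCCCCCCCCCCCc1c(C)c(N(C)C)nc(C)c1O` gives 62% in this assay. Compound 2 `Cc1c(N(C)C)nc(CCCCCCCCCCO)c(O)c1C` gives 24% in this assay, the lowest of the two numbers; its nearest neighbour is compound 1, whose number lies beyond the scatter above it. Within the data shown here, compound 1 carries no hydroxy, and no further pair of measured compounds that differ in one place is available, so the weight of the hydroxy itself cannot be read from a single clean step.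

Compound 3 `CCCCCCCCCCCCCCCCc1nc(N(C)C)c(C)c(C)c1O` has not been measured in this assay. It differs from compound 2 as follows: hexyl in place of hydroxy on a saturated chain carbon, ten or more bonds along the chain from an aromatic carbon. The change removes the only hydroxy of the chain and extends the saturated chain by six carbon atoms.

Given that the one compound without a hydroxy, compound 1, stands at 62% in this assay, compound 3 is expected to move upward from compound 2 by a step beyond the scatter. The step from compound 2 to compound 3 is estimated as a number 28 percentage points higher from compound 2 to compound 3 (beyond the scatter). For compound 3 the expected read-out in this assay is 52%, with a range from 28% to 74%.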

Compound 3, a percentage reported as activity, at one concentration (the size of the read-out at that concentration, not a potency): 67%
Compound 3: the middle estimate sits 15 percentage points below what was measured, within the range that was stated.
By their numbers in this assay, from the lowest: compound 2; then compounds 1 and 3 (each within the scatter of the next).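

The series now has its first step between compounds that differ in one place: in this assay, hexyl in place of hydroxy on a saturated chain carbon, ten or more bonds along the chain from an aromatic carbon, gives a number 43 percentage points higher from compound 2 to compound 3 (beyond the scatter). This change at so remote a chain position is therefore enough to move the read-out at the tested concentration by a large margin, and the comparison no longer has to go through compounds that differ elsewhere as well. Among these compounds, the single step removes the hydroxy and adds the hexyl together, and no information on the compounds bears on the origin of the rise.

The compounds shown leave open how much of the step belongs to the loss of the hydroxy and how much to the added hexyl; methyl in place of hydroxy at this position would begin to separate the two. Also open, as far as these compounds go, are how an amine or a carboxylic acid in place of hydroxy would read here, whether a longer chain would carry the read-out further, and how the step would look as a potency rather than at one concentration.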